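Chain lengthening on a shared core and cytotoxicity

The source may hold more compounds than are shown below. What is called first, only, known or untested is meant among the compounds shown, and "the series" means these compounds.

Three compounds built on one core have been examined in a functional assay on T-24 cells (Homo sapiens) for cytotoxicity, read by neutral red uptake, with a stated time of 72 h; a higher number here means a weaker inhibitor, a lower number a stronger inhibitor. Compound 1 `CCCCNc1nc(SC(C)C)nc2ncccc12` gives 12300 nM. Compound 2 `CCCCCNc1nc(SC(C)C)nc2ncccc12` gives 7900 nM. Compound 3 `CCCCCCNc1nc(SCCCC)nc2ncccc12` gives 4500 nM; against compound 1 its number is lower, and that gap lies beyond the scatter, whereas against compound 2 the two numbers sit within the scatter of each other. The difference between the cores of compound 1 and compound 3 is not broken down here.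

Compound 2 differs from compound 1 by methyl in place of hydrogen on a saturated chain carbon, four bonds along the chain from a nitrogen on an aromatic ring and the step was a 1.6-fold lower number from compound 1 to compound 2 (0.19 log units; within the scatter).

Compound 4 `CCCCCCNc1nc(SCCCCC)nc2ncccc12` is not yet measured. It differs from compound 3 by methyl in place of hydrogen on a saturated chain carbon, four bonds along the chain from a sulfur. Going by the values given here, this is the same kind of change as the one from compound 1 to compound 2, but at a different place: there the methyl entered four bonds along the chain from a nitrogen on an aromatic ring, here four bonds along the chain from a sulfur.

For compound 4 the step is expected to be a 1.4-fold lower number from compound 3 to compound 4 (0.15 log units; within the scatter), resting on the small lowering seen in a 1.6-fold lower number from compound 1 to compound 2 (0.19 log units; within the scatter). Compound 4 is therefore estimated at 3200 nM, with a range from 1500 nM to 7000 nM in this assay.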

Compound 4, half-maximal inhibitory concentration: 18500 nM
Estimate against measurement, compound 4: 5.8-fold (0.76 log units) below; measured number outside the range, above it.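

In this assay the added methyl, four bonds along the chain from a sulfur, gave a 4.1-fold higher number from compound 3 to compound 4 (0.61 log units; beyond the scatter) and so marked a weaker inhibitor, whereas the earlier step did not move the number beyond the scatter. The same change therefore did not carry over from one core to the other with the same result, and the two steps differ: the same change on two cores in this assay, a 1.6-fold lower number (0.19 log units; within the scatter) from compound 1 to compound 2 and a 4.1-fold higher number (0.61 log units; beyond the scatter) from compound 3 to compound 4, 6.4-fold (0.81 log units) apart, beyond the scatter of two such steps. This rests on a single pair for each core, and the methyl sits at a different place in each pair, four bonds along the chain from a nitrogen on an aromatic ring in one and from a sulfur in the other, so it does not show whether the core or the place decides the outcome.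

The compounds shown leave open whether a longer chain on the sulfur, such as hexyl, would raise the number further, and how a chain longer than hexyl on the nitrogen would behave. They also leave open how a chain ending in an amine or a carboxylic acid would read in this assay.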